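A few compounds are considered here, and "the series" means these few. Any claim that something is new, unique, unknown or untested is made for them only; others in the source may bear on it.

Series notes. Compound 1 `N=C(N)NCCCOc1ccc(CNc2nc3ccc(Oc4cccc(C(F)(F)F)c4)cc3s2)cc1` is the reference point. Going by the values given here, in an assay on cells for inhibition of Voltage-dependent T-type calcium channel subunit alpha-1H (Homo sapiens), read by FLIPR and calcium flux, with stated times of 600 s and 300 s (a higher number here means a weaker inhibitor, a lower number a stronger inhibitor), compound 1 gives 270000 nM, the second highest of the three numbers measured so far. Compound 2 `N=C(N)NCCCOc1ccc(CNc2nc3ccc(Oc4ccc(F)cc4)cc3s2)cc1` gives 288000 nM in this assay, and compound 3 `N=C(N)NCCCOc1ccc(CNc2nc3ccc(Oc4ccc(C(F)(F)F)cc4)cc3s2)cc1` gives 195000 nM. All steps among these three sit on the aryl ether of the shared core: a 1.1-fold higher number from compound 1 to compound 2 (0.03 log units; within the scatter), a 1.4-fold lower number from compound 1 to compound 3 (0.14 log units; within the scatter) and a 1.5-fold lower number from compound 2 to compound 3 (0.17 log units; within the scatter). Each of them is within the scatter, so nothing yet separates the three measured compounds.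

Compound 4 `NCCCOc1ccc(CNc2nc3ccc(Oc4cccc(C(F)(F)F)c4)cc3s2)cc1` differs from compound 1 at the other end of the molecule: a hydrogen atom in place of a group of 3 heavy atoms (1 carbon, 2 nitrogen; no ring), on an amine nitrogen. Among the compounds with values here, none of the measured steps touches this amine nitrogen, so there is no step to lean on for size or direction here. What the measured compounds do show is that the changes made so far leave the number unmoved in this assay, and the expectation is that compound 4 will likewise stay near the level of compound 1, with no change at the digits printed from compound 1 to compound 4 (within the scatter) expected to fall within the scatter. Within the data shown here, no measured step bears on this position, so the range is kept wide. Compound 4 is estimated at 270000 nM in this assay, with a range of 100000 nM to 700000 nM.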

Compound 4, half-maximal inhibitory concentration: 171000 nM
Estimate against measurement, compound 4: 1.6-fold (0.20 log units) above; low and high end bracket the measured number.
By their numbers in this assay, from the lowest: compounds 4, 3, 1 and 2 (each within the scatter of the next).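

Going by these compounds alone, on the amine nitrogen, whose other neighbour is a saturated chain carbon, a hydrogen atom in place of the group of 3 heavy atoms (1 carbon, 2 nitrogen; no ring) gives a 1.6-fold lower number from compound 1 to compound 4 (0.20 log units; within the scatter) and is the first reading at this position. In this assay, within the data shown here, this end of the molecule therefore tolerates the loss of that group with no step beyond the scatter, so the aryl ether is no longer the only site where a change leaves the number unmoved. No measurement available here speaks to the reason for this result.

Still open, as far as these compounds go, is whether any group on this amine nitrogen can move the number beyond the scatter, in either direction. An acetyl group or a longer chain carrying a carboxylic acid in that place would test this on the shared core.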